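Swapping methoxy for phenyl under a cytotoxicity limit

The source may report more compounds than this note shows. Statements on the series, on what has been measured and on what is new or still open speak of the compounds shown alone.

Values so far in an ADME assay on MDBK cells (Bos taurus) for cytotoxicity (a lower number here means that less compound is tolerated, a higher number that more compound is tolerated), are as follows:
Compound 1 `COc1cccc(Cn2ccc3nc(-c4ccccc4)nc-3c2)c1` gives > 100000 nM as a limit
Compound 2 `COc1ccc(Cn2ccc3nc(-c4ccccc4)nc-3c2)cc1` gives > 100000 nM as a limit
Compound 3 `Brc1ccccc1Cn1ccc2nc(-c3ccccc3)nc-2c1` gives > 100000 nM as a limit

Compound 2 stands at > 100000 nM in this assay, which is a limit of the assay and not a number. Going by the values given here, the wider picture is the same, with the limit of > 100000 nM in this assay, at which 3 of the 3 values shown sit, as the only reading available.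

Compound 4 `c1ccc(-c2ccc(Cn3ccc4nc(-c5ccccc5)nc-4c3)cc2)cc1` carries phenyl in place of methoxy on an aromatic carbon, para to a large group. Among the compounds with values here, two measured steps bear on this change, as both alter the same substituted phenyl. Within the data shown here, the first is a step that the two limits leave unreadable from compound 1 to compound 2 and the second is a step that the two limits leave unreadable from compound 2 to compound 3. Neither has a size that can be read, and phenyl does not appear at this place in any measured compound. The expectation therefore rests on the limit of > 100000 nM in this assay, at which 3 of the 3 values shown sit, and not on a measured step. No step beyond the scatter is expected in this assay, although a readable value cannot be excluded. The expected step is a number no higher from compound 2 to compound 4 (the limit leaves the size open) as an estimate. For compound 4 the estimated value is 100000 nM, with an expected range from 40000 nM to 200000 nM in this estimate.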

Compound 4, half-maximal cytotoxic concentration: 18000 nM
The estimate for compound 4 lay 5.6-fold (0.74 log units) above the measured number, outside the stated range (below it).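

In this assay, the place that holds methoxy in compound 2 proves able to move the read-out: with phenyl there, the result is an at least 5.5-fold lower number from compound 2 to compound 4 (0.74 log units; beyond the scatter). This gives the series its first readable number, since the steps among compound 1, compound 2 and compound 3 cannot be read, and it shows that the substituent on this aromatic carbon can bring less tolerated compound into the measurable range, while the rest of the series stays at the limit: the limit of > 100000 nM in this assay, at which 3 of the 4 values shown sit. Compound 2 has only a limit, so the step fixes how small the change can be but not its full size.

The compounds shown leave open whether the lower number goes with phenyl itself or would also appear with another group at this place, such as a cyclohexyl ring, a longer chain, an amine or a carboxylic acid. They also leave open whether the same swap of methoxy for phenyl in compound 1 would give a readable number too.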